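The source may hold more compounds than are shown below. What is called first, only, known or untested is meant among the compounds shown, and "the series" means these compounds.

Values in an ADME assay on HFF cells (Homo sapiens) for cytotoxicity, read by MTT assay, with a stated time of 72 h; a lower number here means a stronger inhibitor, a higher number a weaker inhibitor:
- Compound 1 `O=C1O[C@H]([C@@H](O)Cn2cc(-c3cc(C(F)(F)F)cc(C(F)(F)F)c3)nn2)C(OCc2ccccc2)=C1OCc1ccccc1`: 80700 nM
- Compound 2 `CCCCCc1ccc(-c2cn(C/C=C3\OC(=O)C(OCc4ccccc4)=C3OCc3ccccc3)nn2)cc1`: > 100000 nM (a limit)
- Compound 3 `CCCCCc1ccc(-c2cn(C[C@H](O)[C@H]3OC(=O)C(OCc4ccccc4)=C3OCc3ccccc3)nn2)cc1`: > 100000 nM (a limit)

Compound 3 gives no number, only a limit: the limit of > 100000 nM in this assay, at which 2 of the 3 values shown sit. Compound 4 `CC(C)(C)c1cn(C[C@H](O)[C@H]2OC(=O)C(OCc3ccccc3)=C2OCc2ccccc2)nn1` carries tert-butyl in place of 4-pentylphenyl on an aromatic carbon of the five-membered aromatic ring with 3 nitrogen (tert-butyl in place of 4-pentylphenyl on an aromatic carbon). Among the measured compounds shown here, no step between measured compounds is available as a guide. For the measured compounds named here, the one numerical reading, from compound 1, is 80700 nM, and it supports an expectation of weak inhibition. In this assay, no change beyond the scatter is expected, so the expected step is a number no higher from compound 3 to compound 4 (the limit leaves the size open). The estimated value for compound 4 is 100000 nM, with an expected range of 45000 nM to 160000 nM.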

Compound 4, half-maximal inhibitory concentration: 13300 nM
Beside the measured number, compound 4's estimate is 7.5-fold (0.88 log units) above it; the measured number lies below the stated range.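

In this assay, tert-butyl in place of 4-pentylphenyl on an aromatic carbon gives an at least 7.5-fold lower number from compound 3 to compound 4 (0.87 log units; beyond the scatter). Among the compounds shown here, this is the first step read at this position, and it shows that the number responds to the group placed there. For compound 3, > 100000 nM is a limit, so the step has no upper bound.

The compounds shown do not separate loss of the six-membered aromatic ring from loss of heavy atoms. A straight hexyl chain or an amine at this position would bear on that question.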